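Two Fluorines Replace the Methyl on the Amide-Linked Benzyl Group

This account rests on a few compounds, and the source may have more. Where it says the series, first, only, none or still open, it means among the compounds named here.

For the measured compounds named here, compound 2 `Cc1ccc(CNC(=O)/C=C/c2coc3cc(O)ccc3c2=O)cc1` gives 17400 nM in a functional assay on A549 cells (Homo sapiens) for inhibition, read by MTT assay, with a stated time of 48 h (a higher number here means a weaker inhibitor, a lower number a stronger inhibitor), the only number measured so far. Compound 1 `O=C(/C=C/c1coc2cc(O)ccc2c1=O)NCc1ccc(F)cc1` reaches only a limit of the assay, > 100000 nM, in this assay. Going by the values given here, the one measured step, an at least 5.7-fold lower number from compound 1 to compound 2 (0.75 log units; beyond the scatter), is the step that bears on compound 3 `O=C(/C=C/c1coc2cc(O)ccc2c1=O)NCc1ccc(F)cc1F`, which carries 2,4-difluorophenyl in place of 4-methylphenyl on a saturated chain carbon bound to an amide-type nitrogen. Since fluoro in place of methyl points back toward the weaker compound 1, and a second fluoro is added, the number is expected to rise, plausibly to the limit again, as the limit of > 100000 nM in this assay, at which 1 of the 2 values shown sits, shows. The expected step is a 4.6-fold higher number from compound 2 to compound 3 (0.66 log units; beyond the scatter), giving an estimate for compound 3 of 80000 nM, within 25000 nM to 300000 nM.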

Compound 3, half-maximal inhibitory concentration: 6610 nM
The estimate for compound 3 lay 12-fold (1.08 log units) above the measured number, and the stated range ends above it.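

Replacing 4-methylphenyl with 2,4-difluorophenyl gives a 2.6-fold lower number from compound 2 to compound 3 (0.42 log units; beyond the scatter), so fluoro groups on this ring need not weaken the compound. One further fluoro on the ring of compound 1 gives an at least 15-fold lower number from compound 1 to compound 3 (1.17 log units; beyond the scatter), showing that this ring is sensitive to a single added fluoro. Compound 1 itself stands at a limit of the assay, not at a number: the limit of > 100000 nM in this assay, at which 1 of the 3 values shown sits.

Still open, from the compounds shown here alone, is whether a ring bearing chlorine or a methoxy group would lower the number further. The compounds shown also do not explain why the added fluoro has this effect.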